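Swapping 4-ethylcyclohexyl for iodo: an estimate of tolerance

This account rests on a few compounds, and the source may have more. Where it says the series, first, only, none or still open, it means among the compounds named here.

Compound 1 `O=C(NC(=S)Nc1cccc(C(F)(F)F)c1)c1ccccc1`: > 100000 nM
Compound 2 `CC[C@H]1CC[C@H](c2ccc(NC(=S)Nc3cccc(C(F)(F)F)c3)cc2)CC1`: 9000 nM

Going by the values given here, in an ADME assay on MDBK cells (Bos taurus) for cytotoxicity, read by MTT assay, with a stated time of 96 h (a lower number here means that less compound is tolerated, a higher number that more compound is tolerated), compound 2 gives 9000 nM, the only exact number so far. Compound 1 gives > 100000 nM, which is a limit of the assay and not a number.

The next compound, compound 3 `FC(F)(F)c1cccc(NC(=S)Nc2ccc(I)cc2)c1`, differs from compound 2 in one place: iodo in place of 4-ethylcyclohexyl on an aromatic carbon. Among the compounds with values here, no pair of measured compounds shows this change on its own, so the expectation is a loose one. A modest step upward is expected, meaning that somewhat more compound would be tolerated. The estimated change is a 2.2-fold higher number from compound 2 to compound 3 (0.35 log units; beyond the scatter). For compound 3 the estimated value is 20000 nM, with an expected range from 6000 nM to 70000 nM.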

Compound 3, half-maximal cytotoxic concentration: 9500 nM
Compound 3: middle estimate off by 2.1-fold (0.32 log units), on the high side, and the stated range covers the measured number.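

In this assay, the swap gives a 1.1-fold higher number from compound 2 to compound 3 (0.02 log units; within the scatter), so the two compounds cannot be told apart. Going by these compounds alone, this is the first view of this aromatic carbon: a group of 8 heavy atoms, with a non-aromatic ring and 2 defined stereocentres, and a single iodine atom leave the cells tolerating about the same amount of compound, at least for this one pair. Nothing shown here explains why these two very different groups give matching numbers.

Going by these compounds, whether an amine, a carboxylic acid or a longer chain on the same carbon would also leave the number unchanged remains open. On these data alone, it is also open whether this swap would behave the same way on any core other than the one shared by these two compounds.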